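A Substituent Swap With Both Anchors at the Assay Limit

A few compounds are considered here, and "the series" means these few. Any claim that something is new, unique, unknown or untested is made for them only; others in the source may bear on it.

In a functional assay on ECa-109 cells (Homo sapiens) for cytotoxicity, read by MTT assay, with a stated time of 72 h (a lower number here means a stronger inhibitor, a higher number a weaker inhibitor), compound 1 `CCOc1ccc(COc2c(OC)cc(/C=C/C(=O)OCC(=O)Nc3ccccc3)cc2OC)cc1` gives only a limit, > 200000 nM. Compound 2 `COc1cc(/C=C/C(=O)OCC(=O)Nc2ccc(Cl)cc2)cc(OC)c1OCc1ccc(Cl)c(Cl)c1` likewise reaches no number in this assay, giving the limit > 200000 nM. Among the measured compounds shown here, compound 2 therefore stands together with compound 1 at the limit of > 200000 nM in this assay, at which 2 of the 2 values shown sit, and no measured step separates them. Compound 3 `CCOc1ccc(COc2c(OC)cc(/C=C/C(=O)OCC(=O)Nc3ccc(Cl)cc3)cc2OC)cc1` differs from compound 2 by 4-ethoxyphenyl in place of 3,4-dichlorophenyl on a saturated chain carbon bound to an oxygen on an aromatic ring. Because both measured compounds sit at the limit of > 200000 nM in this assay, at which 2 of the 2 values shown sit, no step beyond the scatter can be anticipated, and compound 3 is expected to remain at the limit, with an estimated step that the limit leaves unreadable from compound 2 to compound 3. The estimate for compound 3 is 250000 nM, expected within 100000 nM to 1000000 nM.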

Compound 3, half-maximal inhibitory concentration: > 200000 nM
Compound 3: no number, only a limit; the forecaster's own chance of this, stated with the estimate: 80%; the middle value is on the limit's open side.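

Among the compounds shown here, compound 3 in this assay gives only a limit, as do compound 1 and compound 2, so no step among the three can be read: the limit of > 200000 nM in this assay, at which 3 of the 3 values shown sit. The compounds shown leave open how these substituents rank and which change, if any, would bring a readable number.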